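This account rests on a few compounds, and the source may have more. Where it says the series, first, only, none or still open, it means among the compounds named here.

Working notes on the series.

Compound 1 `O=S(=O)(c1cccc(F)c1)c1cn(C2CCNC2)c2cc(Cl)ccc12` carries a chloro on the shared core. In a functional assay on HeLa cells for agonist activity at 5-hydroxytryptamine receptor 6 (Homo sapiens), read by cAMP accumulation and immunoassay, with a stated time of 10 min (a higher number here means a larger maximal response, a lower number a smaller maximal response), compound 1 stands at "not determined" (no result reported), so there is no number from which to place it. Within the data shown here, the only measured member of the set is compound 2 `CCN1CCCC(n2cc(S(=O)(=O)c3cccc(F)c3)c3cc(OC)ccc32)C1`, which differs from compound 1 at several places at once; in this assay compound 2 gives 50%. Among the measured compounds shown here, no pair of measured compounds differing in one place is available, so nothing can be said about how a single change moves the read-out here.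

Compound 3 `O=S(=O)(c1cccc(F)c1)c1cn(C2CCNC2)c2ccccc12` is the next compound to be run in this assay. Its difference from compound 1 is hydrogen in place of chloro on an aromatic carbon. For the measured compounds named here, with no number for compound 1 and no comparable step anywhere in the set, no direction and no size can be given for the change in this assay from compound 1 to compound 3; a shift beyond the scatter in either sense, or none at all, is equally open on the present data.

Going by the values given here, the only anchor is compound 2, which gives 50% in this assay, and that value rests on a differently substituted core. On that anchor alone the largest response for compound 3 in this assay is expected near 50%, with a wide estimated range from 20% to 90%.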

Compound 3, largest response reached (Emax), in percent of the reference or control that the assay uses: 38%
Compound 3: middle estimate off by 12 percentage points, on the high side, and the stated range covers the measured number.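

No step can be read between compound 1 ("not determined" (no result reported)) and compound 3 (38%) in this assay, since compound 1 has no number to compare. The compounds shown leave open how hydrogen in place of chloro on the shared core moves the largest response. No measured evidence bears on this result.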